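Swapping the aryl ether of compound 2 for 3-methylphenyl

The source may report more compounds than this note shows. Statements on the series, on what has been measured and on what is new or still open speak of the compounds shown alone.

Measured compounds:
compound 1 `Cc1nnsc1CO/N=C/c1c(C)nn(C)c1Oc1cccc(C(F)(F)F)c1`, with > 50000 nM in a functional assay on PANC-1 cells (Homo sapiens) for inhibition, read by MTT assay, with a stated time of 48 h; on this read-out higher numbers stand for weaker inhibition and lower numbers for stronger inhibition (this value is a limit of the assay, not a number)
compound 2 `Cc1nnsc1CO/N=C/c1c(C)nn(C)c1Oc1ccc(Br)cc1`, with 12800 nM in this assay

Compound 2 holds the only measured number shown; the other value is a limit, as noted in the limit of > 50000 nM in this assay, at which 1 of the 2 values shown sits. Compound 3 `Cc1cccc(Oc2c(/C=N/OCc3snnc3C)c(C)nn2C)c1` has not been measured. It differs from compound 2 in one place: 3-methylphenyl in place of 4-bromophenyl on an oxygen on an aromatic ring. Among the compounds with values here, no measured step between two compounds tells how large such a change can be here. Within the data shown here, with only one number and one limit to go on, a small weakening is expected, close to the scatter. Compound 3 is expected to give about 25000 nM in this assay, somewhere between 8000 nM and 80000 nM, which means an expected step of a 2.0-fold higher number from compound 2 to compound 3 (0.29 log units; within the scatter).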

Compound 3, half-maximal inhibitory concentration: > 50000 nM
Compound 3 gave a limit, no number; the forecaster's own chance of this, stated with the estimate: 35%; middle value at least 2.0-fold (0.30 log units) away from the limit.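

Within the data shown here, this is the first readable step at this oxygen-linked aryl group: in this assay, 3-methylphenyl in place of 4-bromophenyl gives an at least 3.9-fold higher number from compound 2 to compound 3 (0.59 log units; beyond the scatter). The value for compound 3 is a limit, so this step gives only a minimum size, but it shows that the activity of compound 2 depends on the aryl group, even though both groups have the same heavy-atom count. Compound 2 is now the only compound with a measured number, and the other two sit at the same limit: the limit of > 50000 nM in this assay, at which 2 of the 3 values shown sit.

The step between compound 1 and compound 3 cannot be read, so methyl and trifluoromethyl cannot be ranked. Because the swap alters both the substituent and its ring position, the compounds shown cannot separate those two effects, which 4-methylphenyl or 3-bromophenyl could help to resolve.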